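The source may hold more compounds than are shown below. What is called first, only, known or untested is meant among the compounds shown, and "the series" means these compounds.

Three related compounds, compound 1 (`COc1ccc(-c2cc(NC(=O)C(Cl)Cl)cc(-c3ccc(OC)cc3)c2)cc1`), compound 2 (`O=C(Nc1cccc(-c2ccc(-c3ccccc3)cc2)c1)C(Cl)Cl`) and compound 3 (`CSc1ccc(-c2cc(NC(=O)C(Cl)Cl)cc(-c3ccc(SC)cc3)c2)cc1`), were examined in a functional assay on KB 3-1 cells (Homo sapiens) for cytotoxicity, read by MTT assay, with a stated time of 68 h (on this read-out lower numbers stand for stronger inhibition and higher numbers for weaker inhibition), and none of them gave a number. Compound 1 reached only a limit, > 30000 nM. Compound 3 likewise reached only a limit, > 30000 nM. Compound 2 also stands at a limit, > 50000 nM. Compound 2 therefore has no measured potency to set against the others, and the set offers only two ceilings: the limit of > 30000 nM in this assay, at which 2 of the 3 values shown sit, and (the limit of > 50000 nM in this assay, at which 1 of the 3 values shown sits).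

Compound 4 (`O=C(Nc1cccc(-c2ccc(C(F)(F)F)cc2)c1)C(Cl)Cl`) departs from compound 2 at one place, with trifluoromethyl in place of phenyl on an aromatic carbon, para to a large group (trifluoromethyl in place of phenyl on an aromatic carbon). Among the compounds with values here, no two measured compounds differ in just one place, so this assay gives no direct guide to the size of such a change. With all three tested compounds at limits, no step beyond the usual scatter is expected in this assay, and no direction is favoured. That expectation rests chiefly on compound 2, whose reading is the limit > 50000 nM. The estimated step, an at least 1.2-fold lower number from compound 2 to compound 4 (0.09 log units; that floor lies within the scatter), is accordingly expected to be small, and a report as a limit alone is the likeliest outcome. For compound 4 the estimate is 40000 nM, with an expected range from 15000 nM to 60000 nM.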

Compound 4, half-maximal inhibitory concentration: > 50000 nM
Compound 4 gave a limit, no number (the forecaster's own chance of this, stated with the estimate: 85%); middle value at least 1.2-fold (0.09 log units) away from the limit.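

Compound 2 and compound 4 both stand at limits in this assay, so the step between them, trifluoromethyl in place of phenyl on an aromatic carbon, cannot be read: the limit of > 50000 nM in this assay, at which 2 of the 4 values shown sit.

The compounds shown leave open whether any of them would give a measured potency in this assay, and whether this change alters it at all.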